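One Substitution on the Carbonyl Carbon of Compound 1

The source may hold more compounds than are shown below. What is called first, only, known or untested is meant among the compounds shown, and "the series" means these compounds.

Measured compounds:
compound 1 `CSc1ccc(NC(=O)N[C@@H]2C3CCN(CC3)[C@@H]2Cc2cccnc2)cc1`: > 10000 nM
compound 2 `O=C(Nc1ccc(-c2ccccc2)cc1)N[C@@H]1C2CCN(CC2)[C@@H]1Cc1cccnc1`: > 10000 nM

In an assay on a protein complex for binding affinity to Neuronal acetylcholine receptor; alpha4/beta2 (Homo sapiens) (a lower number here means a stronger inhibitor, a higher number a weaker inhibitor), compound 1 gives > 10000 nM, which is a limit of the assay and not a number. Compound 2 gives > 10000 nM in this assay, likewise only a limit. Among the measured compounds shown here, the single measured step, a step that the two limits leave unreadable from compound 1 to compound 2, cannot be sized because both values sit at the limit of > 10000 nM in this assay, at which 2 of the 2 values shown sit.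

Compound 3 `C/C(=C\C(=O)N[C@@H]1C2CCN(CC2)[C@@H]1Cc1cccnc1)c1ccccc1` differs from compound 1 in one place: 2-phenylprop-1-en-1-yl in place of (4-(methylsulfanyl)phenyl)amino on a carbonyl carbon. For the measured compounds named here, no measured step bears on this change, since the one step available is unreadable, so the expectation rests on the limit of compound 1 alone. Compound 3 is therefore expected to sit near the same limit, estimated at 10000 nM with a range from 2000 nM to 50000 nM. That estimate means an expected step of a number no higher from compound 1 to compound 3 (the limit leaves the size open), with a fair chance that this assay again reports only a limit.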

Compound 3, inhibition constant: > 10000 nM
Compound 3 gave a limit, no number; the forecaster's own chance of this, stated with the estimate: 65%; the middle value sits exactly at the limit.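

The step from compound 1 to compound 3 cannot be read, as both values are limits and not numbers: the limit of > 10000 nM in this assay, at which 3 of the 3 values shown sit.

The compounds shown leave open how strongly each one actually binds, and whether swapping (4-(methylsulfanyl)phenyl)amino for 2-phenylprop-1-en-1-yl on the carbonyl carbon changes that binding at all.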